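Cyclohexylmethyl on the Aromatic Nitrogen: Expected Potency

A few compounds are considered here, and "the series" means these few. Any claim that something is new, unique, unknown or untested is made for them only; others in the source may bear on it.

Measured compounds:
compound 1 `CC(C)c1onc(-c2c(Cl)cccc2Cl)c1COc1ccc(-c2nc3ccc(C(=O)O)cc3n2C(C)C)cc1`: 56.7 nM
compound 2 `CC(C)c1onc(-c2c(Cl)cccc2Cl)c1COc1ccc(-c2nc3ccc(C(=O)O)cc3n2C2CCC2)cc1`: "not determined" (no result reported)
compound 3 `CC(C)c1onc(-c2c(Cl)cccc2Cl)c1COc1ccc(-c2nc3ccc(C(=O)O)cc3n2C2CCCCC2)cc1`: "not determined" (no result reported)

In an assay on isolated protein for agonist activity at Bile acid receptor (Homo sapiens), read by TR-FRET (on this read-out lower numbers stand for an effect already at smaller amounts and higher numbers for an effect only at larger amounts of compound), compound 1 gives 56.7 nM. For compound 2 the result is "not determined" (no result reported), and for compound 3 it is likewise "not determined" (no result reported). So compound 3 stands without a number, and the same holds for compound 2; only compound 1 supplies a measured value in this assay within this set.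

Compound 4 `CC(C)c1onc(-c2c(Cl)cccc2Cl)c1COc1ccc(-c2nc3ccc(C(=O)O)cc3n2CC2CCCCC2)cc1` differs from compound 3 by one change: cyclohexylmethyl in place of cyclohexyl on an aromatic nitrogen. Among the measured compounds shown here, no measured step between two compounds of this set exists, so the size of the step from compound 3 to compound 4 in this assay cannot be read from data; with compound 3 undetermined, no direction can be stated either. For the measured compounds named here, the only anchor is compound 1, which carries a different group on the same aromatic nitrogen and gives 56.7 nM.

Compound 4 is therefore expected to give about 70 nM in this assay, with a wide range from 15 nM to 350 nM.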

Compound 4, half-maximal effective concentration: 19.9 nM
For compound 4 the middle estimate is 3.5-fold (0.55 log units) above the measured one; the measured number falls inside the stated range.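

In this assay, cyclohexylmethyl in place of isopropyl on the aromatic nitrogen gives a 2.8-fold lower number from compound 1 to compound 4 (0.45 log units; beyond the scatter), a modest change but one beyond the usual scatter. Among the compounds shown here, this is the first readable step at this position, and it shows that the nitrogen can carry a group with a carbon-only ring while activity is kept and even somewhat improved. No separate measurement here accounts for this gain.

Steps involving compound 2 or compound 3 cannot be read, so it remains open whether cyclohexylmethyl differs from cyclohexyl, the group it replaces in compound 3. Also open, going by these compounds, is how this position would respond to a benzyl group, a longer chain such as 2-cyclohexylethyl, or a ring containing an amine, such as piperidinylmethyl.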